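Pentyl in place of isopropyl on the amide nitrogen

A few compounds are considered here, and "the series" means these few. Any claim that something is new, unique, unknown or untested is made for them only; others in the source may bear on it.

Compound 1 `CNC(=O)CC[C@H](NS(=O)(=O)c1ccc([N+](=O)[O-])cc1)C(=O)O` and compound 2 `CC(C)NC(=O)CC[C@H](NS(=O)(=O)c1ccc([N+](=O)[O-])cc1)C(=O)O` share one core and differ only at the amide-type nitrogen. In a functional assay on U-937 cells (Homo sapiens) for cytotoxicity, read by MTT assay, with a stated time of 48 h (a higher number here means a weaker inhibitor, a lower number a stronger inhibitor), compound 1 gives the limit > 500000 nM, not a number. In this assay, going by the values given here, compound 2 gives 95100 nM, the only number measured so far. Among the compounds with values here, the one measured step, an at least 5.2-fold lower number from compound 1 to compound 2 (0.72 log units; beyond the scatter), bears directly on compound 3 `CCCCCNC(=O)CC[C@H](NS(=O)(=O)c1ccc([N+](=O)[O-])cc1)C(=O)O`, which carries the change (pentyl in place of isopropyl on an amide-type nitrogen). Because the larger group lowered the number an at least 5.2-fold lower number from compound 1 to compound 2 (0.72 log units; beyond the scatter), a further lowering is expected. Compound 3 is estimated at 30000 nM in this assay, between 8000 nM and 120000 nM. The expected step is a 3.2-fold lower number from compound 2 to compound 3 (0.50 log units; beyond the scatter).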

Compound 3, half-maximal inhibitory concentration: 32100 nM
The estimate for compound 3 lay 1.1-fold (0.03 log units) below the measured number, and the stated range covers the measured number.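

In this assay, the number keeps falling beyond isopropyl on this amide-type nitrogen, with a 3.0-fold lower number from compound 2 to compound 3 (0.47 log units; beyond the scatter), so the order methyl, isopropyl, pentyl holds across all three compounds, and none goes against it. Over the whole series the change gives an at least 15-fold lower number from compound 1 to compound 3 (1.19 log units; beyond the scatter). That step has only one measured end, as compound 1 gives a limit and not a number: the limit of > 500000 nM in this assay, at which 1 of the 3 values shown sits.

Still open, as far as these compounds go, is whether a chain longer than pentyl lowers the number further or the trend stops. Also open, from the compounds shown here alone, is how a cyclohexyl or phenyl ring, or a terminal amine or carboxylic acid on the chain, would compare.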